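The compounds below may be only part of what the source reports. "The series", "measured", "known", "first", "only" and "open" are said of these compounds alone.

Among the compounds with values here, in a physicochemical assay, read by spectrophotometry, with a stated time of 30 min (on this read-out higher numbers stand for weaker inhibition and lower numbers for stronger inhibition), compound 1 `O=C(CCc1nc2ccccc2c(=O)[nH]1)N/N=C/c1ccc(O)cc1` gives 238000000 nM as the highest of the two numbers measured so far, which makes it the weaker inhibitor of the pair. Compound 2 `COc1cc(/C=N/NC(=O)CCCc2nc3ccccc3c(=O)[nH]2)cc(OC)c1OC` gives 106000000 nM as the lower number, by a margin beyond the usual scatter. Compound 3 `O=C(CCc1nc2ccccc2c(=O)[nH]1)N/N=C/c1ccccc1` has not been measured yet. It differs from compound 1 in one place, where hydrogen stands in place of hydroxy on an aromatic carbon (hydrogen in place of hydroxy on an aromatic carbon), so that 4-hydroxyphenyl becomes phenyl. Within the data shown here, no two measured compounds differ in a single place, so nothing measured shows directly how large this change will be. A small step toward a higher number in this assay is expected, and a 1.3-fold higher number from compound 1 to compound 3 (0.10 log units; within the scatter) is the estimated step, which may not clear the scatter. Compound 3 is estimated at 300000000 nM with an expected range from 100000000 nM to 900000000 nM in this measurement.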

Compound 3, half-maximal inhibitory concentration: 734000000 nM
The estimate for compound 3 lay 2.4-fold (0.39 log units) below the measured number, within the range that was stated.
By their numbers in this assay, from the lowest: compound 2; then compound 1; then compound 3.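

Going from hydroxy to hydrogen on this aromatic carbon, para to a large group, gives in this assay a 3.1-fold higher number from compound 1 to compound 3 (0.49 log units; beyond the scatter), so inhibition is weaker once the hydroxy is gone. Within the data shown here, this is the first direct reading of this position, and although the step is modest, it clears the usual scatter, so the loss of this single group makes a real difference to the number. Nothing at hand shows what lies behind this step.

This one step cannot tell how a methoxy, an amine or a carboxylic acid on the same carbon would read. It also leaves open whether the hydroxy would give a similar step elsewhere on the ring, or on a compound with a longer chain.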